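This account rests on a few compounds, and the source may have more. Where it says the series, first, only, none or still open, it means among the compounds named here.

Among the compounds with values here, in a functional assay on A-375 cells (Homo sapiens) for activation, with a stated time of 3 days (on this read-out lower numbers stand for an effect already at smaller amounts and higher numbers for an effect only at larger amounts of compound), compound 2 (`O=C(Nc1ccc(-c2cscn2)cc1)C1CCCN(Cc2ccccc2F)C1`) gives 7000 nM, the higher of the two numbers so far, while compound 1 (`O=C(Nc1ccc(-c2cscn2)cc1)C1CCCN(Cc2ccc(F)c(F)c2)C1`) gives 1240 nM. Compound 3 (`O=C(Nc1ccc(-c2cscn2)cc1)C1CCCN(Cc2cccc(F)c2)C1`) differs from compound 2 in one place: 3-fluorophenyl in place of 2-fluorophenyl on a saturated chain carbon bound to an amine nitrogen in a ring. Within the data shown here, the only measured step bearing on this is a 5.6-fold higher number from compound 1 to compound 2 (0.75 log units; beyond the scatter), where 2-fluorophenyl replaced 3,4-difluorophenyl. The name 3-fluorophenyl shares part of its pattern with the 3,4-difluorophenyl of compound 1. Compound 1 gives 1240 nM, and a partial return towards that number is expected. The expected step is a 2.5-fold lower number from compound 2 to compound 3 (0.40 log units; beyond the scatter), modest and towards a lower number. For compound 3 the estimate is 2800 nM, with an expected range of 1000 nM to 7500 nM.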

Compound 3, half-maximal effective concentration: 5000 nM
Estimate against measurement, compound 3: 1.8-fold (0.25 log units) below; measured number inside the range.
By their numbers in this assay, from the lowest: compound 1; then compounds 3 and 2 (each within the scatter of the next).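

In this assay, 3-fluorophenyl in place of 2-fluorophenyl gives a 1.4-fold lower number from compound 2 to compound 3 (0.15 log units; within the scatter), so these two placements of a single fluoro are not told apart here. Hydrogen in place of fluoro on an aromatic carbon gives a 4.0-fold higher number from compound 1 to compound 3 (0.61 log units; beyond the scatter), so among the compounds shown, only the 3,4-difluorophenyl of compound 1 stands apart from both monofluoro groups. Nothing measured on hand gives a reason for this. Still open, as far as these compounds go, is whether chloro or methoxy in place of fluoro on this ring would match compound 1 or compound 3.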